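A few compounds are considered here, and "the series" means these few. Any claim that something is new, unique, unknown or untested is made for them only; others in the source may bear on it.

Measured in a functional assay on MCF7 cells (Homo sapiens) for antiproliferative activity, read by MTT assay, with stated times of 24 h and 72 h; a higher number here means a weaker inhibitor, a lower number a stronger inhibitor:
Compound 1 `COc1cc([C@@H]2[C@H](Oc3ccccc3)C(=O)N2c2cc(OC)c(OC)c(OC)c2)cc(OC)c1OC`: 29000 nM
Compound 2 `COc1ccc([C@@H]2[C@H](Oc3ccccc3)C(=O)N2c2cc(OC)c(OC)c(OC)c2)cc1`: 35000 nM
Compound 3 `COc1cc(N2C(=O)[C@@H](Oc3ccccc3)[C@H]2c2ccc(O)cc2)cc(OC)c1OC`: 48000 nM

Compound 2 stands within the scatter of both neighbours, with a 1.2-fold higher number from compound 1 to compound 2 (0.08 log units; within the scatter) and a 1.4-fold higher number from compound 2 to compound 3 (0.14 log units; within the scatter). The third pair shows a 1.7-fold higher number from compound 1 to compound 3 (0.22 log units; within the scatter). Compound 4 `COc1ccc([C@@H]2[C@H](Oc3ccccc3)C(=O)N2c2cc(OC)c(OC)c(OC)c2)cc1NC(=O)C(C)N` follows from compound 2 by one change: ((1-aminoethyl)carbonyl)amino in place of hydrogen on an aromatic carbon. The new group, ((1-aminoethyl)carbonyl)amino, sits ortho to a methoxy group and meta to a large group.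

The closest evidence is the exchange of 3,4,5-trimethoxyphenyl for 4-methoxyphenyl, which gave a 1.2-fold higher number from compound 1 to compound 2 (0.08 log units; within the scatter). The exchange for 4-hydroxyphenyl gave a 1.7-fold higher number from compound 1 to compound 3 (0.22 log units; within the scatter), and removing the methyl gave a 1.4-fold higher number from compound 2 to compound 3 (0.14 log units; within the scatter). All three steps stay within the scatter, yet none involves a chain of this kind, so they set no firm limit on this larger change. A lower number is tentatively expected in this assay, though the data do not establish that direction. For compound 4 the estimated value is 3000 nM, with an expected range of 150 nM to 40000 nM. The expected change is a 12-fold lower number from compound 2 to compound 4 (1.07 log units; beyond the scatter).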

Compound 4, half-maximal inhibitory concentration: 9200 nM
For compound 4 the middle estimate is 3.1-fold (0.49 log units) below the measured one, within the range that was stated.
By their numbers in this assay, from the lowest: compound 4; then compounds 1, 2 and 3 (each within the scatter of the next).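

In this assay, the aromatic carbon ortho to a methoxy group and meta to a large group takes ((1-aminoethyl)carbonyl)amino with a 3.8-fold lower number from compound 2 to compound 4 (0.58 log units; beyond the scatter), and the number falls rather than rises. Among these compounds, this is the first step to lie beyond the scatter, whereas the earlier exchanges, all on the aryl group at the saturated ring carbon, stayed within it. It also shows that a substituent of this size at this position is compatible with activity on the core of compound 2, though no measurement shown accounts for the change.

The compounds shown leave open whether the terminal amine of the chain matters, since a simple amino group, an acetylamino group and a longer chain do not appear among them. They also leave open whether a carboxylic acid at this position would give a similar step.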